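Thioether aryl exchange: expectation for compound 3

The source may report more compounds than this note shows. Statements on the series, on what has been measured and on what is new or still open speak of the compounds shown alone.

Compound 1 `COc1ccc(Sc2nc3cc(N)cc(N)c3nc2-c2ccccc2)cc1` in a functional assay on PC-3 cells (Homo sapiens) for inhibition, read by sulforhodamine B assay, with a stated time of 48 h (on this read-out lower numbers stand for stronger inhibition of growth and higher numbers for weaker inhibition of growth), gives 1740 nM.
Compound 2 `Nc1cc(N)c2nc(-c3ccccc3)c(Sc3ccc(Cl)c(Cl)c3)nc2c1` in this assay gives 3470 nM.

Within the data shown here, compound 2 stands at the higher of the two numbers measured, with compound 1 the only neighbour; the gap between them, a 2.0-fold higher number from compound 1 to compound 2 (0.30 log units; within the scatter), lies within the scatter, so no order between the two is claimed. Compound 3 `Nc1cc(N)c2nc(-c3ccccc3)c(Sc3ccc(F)cc3)nc2c1` differs from compound 2 by 4-fluorophenyl in place of 3,4-dichlorophenyl on a sulfur. Among the measured compounds shown here, the single measured step bears directly on this change, since it also exchanges the aryl group on the sulfur: a 2.0-fold higher number from compound 1 to compound 2 (0.30 log units; within the scatter). That step did not move the number beyond the scatter, and the present exchange is of the same kind, so in this assay no step beyond the scatter is expected in either direction; the expected step is a 1.4-fold lower number from compound 2 to compound 3 (0.14 log units; within the scatter). Compound 3 is therefore estimated at 2500 nM, with a range from 900 nM to 7000 nM.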

Compound 3, concentration for 50% growth inhibition: < 100000 nM
Compound 3: only a limit was reported; the forecaster's own chance of this, stated with the estimate: 5%; the middle value does not contradict the limit.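

In this assay compound 3 gives only a limit, < 100000 nM. Among these compounds, no step from compound 1 or compound 2 to compound 3 can be read: the limit of < 100000 nM in this assay, at which 1 of the 3 values shown sits. The compounds shown leave open how the growth inhibition by compound 3 compares with that by compound 1 and compound 2.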